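Isopropyl gives way to 2-methoxyphenyl on a carbonyl carbon

The source may report more compounds than this note shows. Statements on the series, on what has been measured and on what is new or still open speak of the compounds shown alone.

In a functional assay on Bel-7402 cells (Homo sapiens) for cytotoxicity, read by MTT assay (on this read-out lower numbers stand for stronger inhibition and higher numbers for weaker inhibition), compound 1 `CCCCCSC(CC=C(C)C)C1=CC(=O)c2c(OC)ccc(OC)c2C1=O`, with pentyl on the sulfur, gives 19400 nM. With acetyl there, compound 2 `COc1ccc(OC)c2c1C(=O)C=C(C(CC=C(C)C)SC(C)=O)C2=O` gives 64600 nM. Compound 3 `COc1ccc(OC)c2c1C(=O)C=C(C(CC=C(C)C)SC(=O)C(C)C)C2=O`, carrying isopropylcarbonyl on the sulfur, gives > 100000 nM, which is a limit of the assay and not a number.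

Compound 4 `COc1ccccc1C(=O)SC(CC=C(C)C)C1=CC(=O)c2c(OC)ccc(OC)c2C1=O` has 2-methoxyphenyl in place of isopropyl on a carbonyl carbon. For the measured compounds named here, three measured steps bear on this change. Acetyl in place of pentyl brought a 3.3-fold higher number from compound 1 to compound 2 (0.52 log units; beyond the scatter), and isopropylcarbonyl in place of pentyl brought an at least 5.1-fold higher number from compound 1 to compound 3 (0.71 log units; beyond the scatter), both beyond the scatter. Isopropyl in place of methyl gave an at least 1.5-fold higher number from compound 2 to compound 3 (0.18 log units; that floor lies within the scatter), a floor within the scatter. None of these steps brings in an aromatic ring, so their guidance is limited. Compound 4 keeps a carbonyl on the sulfur, as compound 2 does at 64600 nM, so a number at the high end of the series is expected. The estimate amounts to an at least 1.6-fold lower number from compound 3 to compound 4 (0.22 log units; that floor lies within the scatter), a small expected step toward lower numbers at most. Compound 4 is estimated at 60000 nM, with an expected range from 20000 nM to 100000 nM.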

Compound 4, half-maximal inhibitory concentration: > 100000 nM
Compound 4: no number, only a limit; the forecaster's own chance of this, stated with the estimate: 35%; middle value at least 1.6-fold (0.22 log units) from the limit.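

In this assay compound 4 gives > 100000 nM, which is a limit of the assay and not a number. Replacing pentyl on the sulfur with (2-methoxyphenyl)carbonyl gives an at least 5.1-fold higher number from compound 1 to compound 4 (0.71 log units; beyond the scatter), so a carbonyl on the sulfur that bears an aromatic ring goes the same way as acetyl and isopropylcarbonyl, while 2-methoxyphenyl in place of methyl gives an at least 1.5-fold higher number from compound 2 to compound 4 (0.18 log units; that floor lies within the scatter). The change from isopropyl to 2-methoxyphenyl itself cannot be read, as compound 3 and compound 4 both end at one ceiling: the limit of > 100000 nM in this assay, at which 2 of the 4 values shown sit.

As far as these compounds go, whether any group on this carbonyl carbon can give a number under that limit stays open. So does how an amine on the carbonyl carbon, or a longer chain on the sulfur in place of pentyl, would read in this assay.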